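The source may report more compounds than this note shows. Statements on the series, on what has been measured and on what is new or still open speak of the compounds shown alone.

Measured compounds in a functional assay on HEK293 cells for agonist activity at Free fatty acid receptor 1 (Homo sapiens), read by fluorescence and calcium flux, with a stated time of 10 min; on this read-out higher numbers stand for an effect only at larger amounts of compound and lower numbers for an effect already at smaller amounts:
- compound 1 `CC#C[C@@H](CC(=O)O)c1ccc(OC[C@H]2COc3ccc(Br)cc3O2)cc1`: 210 nM
- compound 2 `CC#C[C@@H](CC(=O)O)c1ccc(OC[C@H]2COc3ccc(C)cc3O2)cc1`: 120 nM
- compound 3 `CC#C[C@@H](CC(=O)O)c1ccc(OC[C@H]2COc3ccc(CO)cc3O2)cc1`: > 30000 nM

Compound 1 and compound 2 sit close together: a 1.8-fold lower number from compound 1 to compound 2 (0.24 log units; within the scatter). Compound 3 is different in kind, as its value is a limit of this assay and not a number; compound 3 stands at the limit of > 30000 nM in this assay, at which 1 of the 3 values shown sits. The two steps that lead into compound 3 are both large and both beyond the scatter: an at least 140-fold higher number from compound 1 to compound 3 (2.15 log units; beyond the scatter) and an at least 250-fold higher number from compound 2 to compound 3 (2.39 log units; beyond the scatter).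

Compound 4 `CC#C[C@@H](CC(=O)O)c1ccc(OC[C@H]2COc3ccc(C(C)=O)cc3O2)cc1` differs from compound 3 by acetyl in place of hydroxymethyl on an aromatic carbon. Within the data shown here, no measured step covers an acetyl on the shared core, so the expectation rests on the steps into compound 3 alone. The step from compound 2 to compound 3 added a hydroxy on the saturated chain carbon, and compound 4 no longer carries that hydrogen-bond donor, while compound 4 still carries an oxygen on the same aromatic carbon rather than bromo or methyl. Compound 4 is therefore expected to recover only part of the way toward compound 1 and compound 2, and may still remain at the limit. The estimated step is an at least 5.0-fold lower number from compound 3 to compound 4 (0.69 log units; beyond the scatter). For compound 4 the estimate is 6000 nM, in the range 600 nM to 30000 nM.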

Compound 4, half-maximal effective concentration: > 30000 nM
Compound 4 gave a limit, no number; the forecaster's own chance of this, stated with the estimate: 35%; middle value at least 5.0-fold (0.69 log units) away from the limit.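

In this assay compound 4 gives > 30000 nM, a limit of the assay and not a number, so the step from compound 3, itself a limit, cannot be read. Acetyl in place of methyl gives an at least 250-fold higher number from compound 2 to compound 4 (2.39 log units; beyond the scatter), and acetyl in place of bromo gives an at least 140-fold higher number from compound 1 to compound 4 (2.15 log units; beyond the scatter). Hydroxymethyl carries 1 hydrogen-bond donor and acetyl 0, so that donor is not required for the loss at this aromatic carbon, and among the compounds shown both oxygen-bearing groups sit at the limit while bromo and methyl do not: the limit of > 30000 nM in this assay, at which 2 of the 4 values shown sit.

On these data alone, whether the loss follows the oxygen itself or some other feature shared by hydroxymethyl and acetyl stays open. A methoxy or an ethyl on this aromatic carbon would bear on that question.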